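Swapping a Methylphenyl for a Dimethoxyphenyl at the Carbonyl

This account rests on a few compounds, and the source may have more. Where it says the series, first, only, none or still open, it means among the compounds named here.

Compound 2 `COc1ccc(-c2cc(/C=C/C(=O)c3ccc(C)cc3)nc3cc(-c4ccccc4)nn23)cc1OC` was tested in a functional assay on DU-145 cells (Homo sapiens) for antiproliferative activity, read by MTT assay, with a stated time of 24 h (a lower number here means a stronger inhibitor, a higher number a weaker inhibitor), where compound 2 gives 26800 nM. Going by the values given here, of the two numbers measured so far it is nominally the top one, yet its only neighbour, compound 1 `COc1ccc(-c2cc(C(=O)/C=C/c3ccccc3)nc3cc(-c4ccccc4)nn23)cc1OC`, gives 15600 nM in this assay, and the step of a 1.7-fold higher number from compound 1 to compound 2 (0.24 log units; within the scatter) stays within the scatter, so the two compounds cannot be told apart. Compound 3 `COc1ccc(C(=O)/C=C/c2cc(-c3ccc(OC)c(OC)c3)n3nc(-c4ccccc4)cc3n2)cc1OC` has not yet been measured. It differs from compound 2 by 3,4-dimethoxyphenyl in place of 4-methylphenyl on a carbonyl carbon. Among the compounds with values here, no measured step touches this spot: the one step available concerns a different part of the molecule. There is therefore no ground to expect a shift beyond the scatter in this assay, and the estimated step of a 1.3-fold lower number from compound 2 to compound 3 (0.13 log units; within the scatter) is set close to nothing. Compound 3 is accordingly expected to give 20000 nM in this assay, with a range from 7000 nM to 60000 nM.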

Compound 3, half-maximal inhibitory concentration: 7200 nM
Beside the measured number, compound 3's estimate is 2.8-fold (0.44 log units) above it; measured number inside the range.
By their numbers in this assay, from the lowest: compound 3; then compounds 1 and 2 (each within the scatter of the next).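

Going by these compounds alone, this is the first readable step at this spot: on a carbonyl carbon, 3,4-dimethoxyphenyl in place of 4-methylphenyl gives in this assay a 3.7-fold lower number from compound 2 to compound 3 (0.57 log units; beyond the scatter) and so a modest change, whereas the one earlier step could not separate its two compounds. The group on this carbonyl carbon can therefore shift the number in this assay, and here the lower number goes with the 3,4-dimethoxyphenyl group. Nothing measured here explains the shift.

A single swap cannot show whether one methoxy group would be enough, or whether both are needed for the change. Nor does it show how far the number would move with a phenyl carrying an amine or a carboxylic acid in this place.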